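Sec-butyl to carbamoylmethyl on the amino acid fragment

The source may report more compounds than this note shows. Statements on the series, on what has been measured and on what is new or still open speak of the compounds shown alone.

In a functional assay on the whole organism (Tail, strain ICR) with Mus musculus as the target, in the tail flick test, with a stated time of 120 min, at a dose of 25 umol/kg by the oral route (a lower number here means a weaker effect, a higher number a stronger effect of the compound at the dose given), compound 1 `O=C(CN(c1nc(Cl)nc2[nH]cnc12)C1CC1)N[C@@H](CO)C(=O)OCc1ccccc1` gives 34.5%. Compound 2 `CC[C@H](C)[C@H](NC(=O)CN(c1nc(Cl)nc2[nH]cnc12)C1CC1)C(=O)O` gives 21.4% in this assay and stands second highest of the three numbers: compound 1 lies higher by a margin beyond the scatter, while compound 3 `O=C(OCc1ccccc1)[C@@H]1CCCN1C(=O)CN(c1ncnc2c1ncn2C1CCCCO1)C1CC1`, which gives 17.5% in this assay, lies within the scatter of compound 2. Within the data shown here, no step between measured compounds that differ in one place is available, so the move to compound 4 `NC(=O)C[C@H](NC(=O)CN(c1nc(Cl)nc2[nH]cnc12)C1CC1)C(=O)O` rests on the structural change alone: carbamoylmethyl in place of sec-butyl on a saturated chain carbon bound to an amide-type nitrogen and a carbonyl carbon. Among the measured compounds shown here, nothing among the measured compounds shows what this change does, so a step in this assay of no more than the usual scatter, in either direction, is expected. Compound 4 is accordingly estimated at 18%, with a range from 5% to 34%, which corresponds to an expected step of a number 3.4 percentage points lower from compound 2 to compound 4 (within the scatter).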

Compound 4, a percentage reported as activity, at one dose (the size of the read-out at that dose, not a potency): 17%
Compound 4: the middle estimate sits 1 percentage points above what was measured, within the range that was stated.
By their numbers in this assay, from the lowest: compounds 4, 3 and 2 (each within the scatter of the next); then compound 1.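

On a saturated chain carbon bound to an amide-type nitrogen and a carbonyl carbon, carbamoylmethyl in place of sec-butyl gives, in this assay, a number 4.4 percentage points lower from compound 2 to compound 4 (within the scatter). Among these compounds, this is the first step that can be read at one place, and it shows that the position accepts one hydrogen-bond donor and one hydrogen-bond acceptor in place of a purely carbon side chain without a step beyond the scatter. No measurement at hand accounts for this outcome.

From the compounds shown here alone, whether an aminomethyl group, a carboxymethyl group or a longer chain on this carbon would depart from compound 2 by more than the scatter remains open. Also open, going by these compounds, is whether the same change would read alike at another dose or time.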